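Pyridin-4-yl for Phenyl: Expected Shift in Vero Tolerance

A few compounds are considered here, and "the series" means these few. Any claim that something is new, unique, unknown or untested is made for them only; others in the source may bear on it.

Measured compounds:
Compound 1 `COc1cc(C2C(C(=O)Nc3ccc(Cl)cc3)=C(C)NC(C)=C2C(=O)Nc2ccc(Cl)cc2)ccc1O`: 250 ug/mL
Compound 2 `CC1=C(C(=O)Nc2ccc(Cl)cc2)C(c2ccncc2)C(C(=O)Nc2ccc(Cl)cc2)=C(C)N1`: 78 ug/mL
Compound 3 `COc1ccc(NC(=O)C2=C(C)NC(=O)NC2c2ccccc2)cc1`: 225 ug/mL

These three values come from an ADME assay on Vero cells (Chlorocebus sabaeus) for cytotoxicity, read by sulforhodamine B assay, with a stated time of 3 days; a higher number here means that more compound is tolerated, a lower number that less compound is tolerated. Among them, compound 3 stands second highest: its value sits within the scatter of that of compound 1, while compound 2 lies beyond the scatter below it.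

The unmeasured compound 4 `COc1ccc(NC(=O)C2=C(C)NC(=O)NC2c2ccncc2)cc1` differs from compound 3 in one place: pyridin-4-yl in place of phenyl on a saturated ring carbon. Within the data shown here, one measured step bears on this change. From compound 1 to compound 2 the same aromatic ring enters at the same kind of position, though there it replaces 4-hydroxy-3-methoxyphenyl rather than phenyl, and the result was a 3.2-fold lower number from compound 1 to compound 2 (0.51 log units; beyond the scatter). A shift of similar direction and somewhat smaller size is therefore expected in this assay for compound 4, since the leaving group here is phenyl rather than the larger substituted ring.

Compound 4 is accordingly estimated at 110 ug/mL, with a likely range from 50 ug/mL to 240 ug/mL. This expectation corresponds to a 2.0-fold lower number from compound 3 to compound 4 (0.31 log units; beyond the scatter).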

Compound 4, half-maximal cytotoxic concentration: 10 ug/mL
Compound 4: middle estimate off by 11-fold (1.04 log units), on the high side, outside the stated range (below it).
By their numbers in this assay, from the lowest: compound 4; then compound 2; then compounds 3 and 1 (each within the scatter of the next).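

In this assay, pyridin-4-yl in place of phenyl on this saturated ring carbon gave a 23-fold lower number from compound 3 to compound 4 (1.35 log units; beyond the scatter) on the core of compound 3. That is a much larger drop than a 3.2-fold lower number from compound 1 to compound 2 (0.51 log units; beyond the scatter) where the same ring replaced 4-hydroxy-3-methoxyphenyl on a different core. Both steps point the same way, but their sizes differ, so the size of this change depends on the group it replaces, on the surrounding core, or on both, and no data here explain the larger drop.

Going by these compounds, it remains open whether the drop follows the ring nitrogen at this particular ring position, which a pyridin-3-yl or pyridin-2-yl group on the same carbon would test. On these data alone, it is also open how far the two cores and the two departing groups each contribute to the difference between the steps.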